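Bombesin receptor subtype-3 series: aryl versus branched alkyl side chain

A few compounds are considered here, and "the series" means these few. Any claim that something is new, unique, unknown or untested is made for them only; others in the source may bear on it.

Measured compounds:
compound 1 `O=C(O)c1ccccc1-c1ccc(CCc2ncc(CCc3ccccc3)[nH]2)cc1`: 1320 nM
compound 2 `N#Cc1cccc(Cc2cnc(CCc3ccc(-c4ccccc4C(=O)O)cc3)[nH]2)c1`: 812 nM
compound 3 `CC(C)CCc1cnc(CCc2ccc(-c3ccccc3C(=O)O)cc2)[nH]1`: 119 nM

In an in vitro functional assay on cells for agonist activity at Bombesin receptor subtype-3 (Homo sapiens), read by luminescence and calcium flux (on this read-out lower numbers stand for an effect already at smaller amounts and higher numbers for an effect only at larger amounts of compound), compound 3 stands lowest of the three, with compound 2 nearest and compound 1 furthest; both gaps are beyond the scatter. The two steps that lead to compound 3 are both substantial: an 11-fold lower number from compound 1 to compound 3 (1.05 log units; beyond the scatter) and a 6.8-fold lower number from compound 2 to compound 3 (0.83 log units; beyond the scatter). Between the two aryl-bearing compounds the step is small: a 1.6-fold lower number from compound 1 to compound 2 (0.21 log units; within the scatter).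

Compound 4 `O=C(O)c1ccccc1-c1ccc(CCc2ncc(Cc3ccccc3)[nH]2)cc1` is not yet measured. It differs from compound 3 as follows: phenyl in place of isobutyl on a saturated chain carbon bound to an aromatic carbon. This is the reverse of the kind of change seen in the two measured steps, in which an aryl group at or near this position gave way to a branched alkyl and the number fell by a large and a modest amount. Both aryl-bearing compounds, compound 1 and compound 2, sit well above compound 3, so an aryl group returning here is expected to push the number back up, beyond the scatter.

The estimated step is a 5.9-fold higher number from compound 3 to compound 4 (0.77 log units; beyond the scatter). Compound 4 is therefore expected to give about 700 nM in this assay, with a likely range from 250 nM to 2000 nM.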

Compound 4, half-maximal effective concentration: 205 nM
Compound 4: middle estimate off by 3.4-fold (0.53 log units), on the high side; measured number below the stated range.
By their numbers in this assay, from the lowest: compounds 3 and 4 (each within the scatter of the next); then compounds 2 and 1 (each within the scatter of the next).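

In this assay, among these compounds, the phenyl of compound 4 and the isobutyl of compound 3 cannot be told apart at this saturated chain carbon bound to an aromatic carbon (a 1.7-fold higher number from compound 3 to compound 4 (0.24 log units; within the scatter)), so compound 4 goes against the reading from the earlier compounds that an aryl group here costs activity as such. The higher numbers of the two earlier aryl compounds now attach to more specific features: removing the nitrile from the ring gives a clear fall (a 4.0-fold lower number from compound 2 to compound 4 (0.60 log units; beyond the scatter)), and so does the change from the benzyl of compound 1 to the phenyl of compound 4 (a 6.4-fold lower number from compound 1 to compound 4 (0.81 log units; beyond the scatter)). Nothing at hand accounts for these differences.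

The compounds shown leave open whether a methoxy group or a chlorine on this phenyl ring would raise the number as the nitrile does, and whether a saturated cyclohexyl ring would stay with compound 3 and compound 4. Among the compounds shown here, it also remains open whether a longer chain ending in an amine would be tolerated at this carbon, since the only groups seen here are hydrocarbon chains and aryl rings.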